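Compound 3 to compound 4: an aryl exchange

The compounds below may be only part of what the source reports. "The series", "measured", "known", "first", "only" and "open" are said of these compounds alone.

In an ADME assay on L6 cells (Rattus norvegicus) for cytotoxicity (on this read-out lower numbers stand for stronger inhibition and higher numbers for weaker inhibition), compound 1 (`O=C(CN1CCN(c2ccc(Cl)cc2)CC1)N1CCN(c2ccc(Cl)cc2)CC1`) gives 116000 nM as its measured number. Compound 2 (`COc1ccc(N2CCN(C(=O)Cn3cnc([N+](=O)[O-])n3)CC2)cc1`) gives 133000 nM in the same read-out. Compound 3 (`N#Cc1ccccc1N1CCN(C(=O)Cn2cnc([N+](=O)[O-])n2)CC1`) gives 213000 nM and lies within the scatter of both, so the three cannot be ranked.

Going by the values given here, compound 4 (`Cc1ccc(N2CCN(C(=O)Cn3cnc([N+](=O)[O-])n3)CC2)cc1`) is still unmeasured and carries 4-methylphenyl in place of 2-cyanophenyl on an amine nitrogen in a ring as its only change. Among the compounds with values here, the one measured step at this place is a 1.6-fold higher number from compound 2 to compound 3 (0.20 log units; within the scatter) with 2-cyanophenyl in place of 4-methoxyphenyl. Within the data shown here, that single step stays within the scatter, and no measured step bears directly on 4-methylphenyl. No change beyond the scatter is therefore expected in this assay, with at most a slight drift toward the number of compound 2. The expected change is a 1.5-fold lower number from compound 3 to compound 4 (0.18 log units; within the scatter) as an estimate only. For compound 4 the estimated value is 140000 nM with an expected range from 70000 nM to 260000 nM in this read-out.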

Compound 4, half-maximal inhibitory concentration: 148000 nM
For compound 4 the middle estimate is 1.1-fold (0.02 log units) below the measured one, within the range that was stated.
By their numbers in this assay, from the lowest: compounds 1, 2, 4 and 3 (each within the scatter of the next).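

In this assay the amine nitrogen in a ring now carries a third aryl group, and the exchange of 2-cyanophenyl for 4-methylphenyl gives a 1.4-fold lower number from compound 3 to compound 4 (0.16 log units; within the scatter) and no readable change. Going by these compounds alone, compound 4 also adds a comparison the earlier compounds did not offer, methyl in place of methoxy on an aromatic carbon, which gives a 1.1-fold higher number from compound 2 to compound 4 (0.05 log units; within the scatter) and again leaves the two compounds indistinguishable in this read-out. No measured information is available to explain either step.

Open, on these data alone, is whether an amine, a carboxylic acid or a longer chain in place of the methyl of compound 4 would move the number beyond the scatter. Also open, as far as these compounds go, is whether a change elsewhere in the core of compound 4 would do so.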